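A few compounds are considered here, and "the series" means these few. Any claim that something is new, unique, unknown or untested is made for them only; others in the source may bear on it.

Measured so far: compound 1 `Cc1cccc(Cn2c(CN3CCN(C(=O)c4ccc(C#N)cc4)CC3)nc3ccccc32)c1` at 20.8%; compound 2 `CC(C)CCn1c(CN2CCN(C(=O)C3CC3)CC2)nc2ccccc21` at 70%.

In an assay on isolated protein for inhibition of aldehyde dehydrogenase 1A1 (Homo sapiens), read by spectrophotometry, tested at 10 uM (a lower number here means less inhibition, a higher number more inhibition at the concentration tested (going by the name of the read-out)), compound 1 gives 20.8%, the lower of the two numbers; compound 2 gives 70%, beyond the scatter above it. Compound 3 `Cc1cccc(Cn2c(CN3CCN(C(=O)C(C)C)CC3)nc3ccccc32)c1` is not yet measured and differs from compound 1 in one place: isopropyl in place of 4-cyanophenyl on a carbonyl carbon. Among the compounds with values here, no measured pair isolates this change, yet compound 2, which also carries no 4-cyanophenyl on its carbonyl carbon, sits well above compound 1 in this assay. An upward step is therefore expected, a number 29.2 percentage points higher from compound 1 to compound 3 (beyond the scatter). Compound 3 is estimated at 50%, between 25% and 75%.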

Compound 3, a percentage reported as inhibition, at one concentration (the size of the read-out at that concentration, not a potency): 87.2%
The estimate for compound 3 lay 37.2 percentage points below the measured number; measured number outside the range, above it.
By their numbers in this assay, from the lowest: compound 1; then compound 2; then compound 3.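

In this assay isopropyl in place of 4-cyanophenyl on a carbonyl carbon gives a number 66.4 percentage points higher from compound 1 to compound 3 (beyond the scatter) as a large step. This pair isolates the change, so the group on this carbonyl carbon alone, with the rest of the structure held fixed, moves the inhibition read-out strongly. Nothing measured here accounts for the size of the step.

Still open, from the compounds shown here alone, is whether the loss in compound 1 follows the nitrile or the phenyl ring itself. An unsubstituted phenyl or a tert-butyl on the same carbonyl carbon would help separate these readings.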